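An Amide Becomes a Urea on a Shared Core

This account rests on a few compounds, and the source may have more. Where it says the series, first, only, none or still open, it means among the compounds named here.

Compound 1 `COc1ccc(C(=O)N(C)c2ccc3[nH]c(-c4n[nH]c5ccccc45)cc3n2)cc1`: 23700 nM
Compound 2 `COc1cccc(C(=O)N(C)c2ccc3[nH]c(-c4n[nH]c5ccccc45)cc3n2)c1`: 22000 nM

Both measured compounds were tested in a functional assay on SMMC-7721 cells (Homo sapiens) for antiproliferative activity, read by MTT assay, with a stated time of 72 h; on this read-out higher numbers stand for weaker inhibition and lower numbers for stronger inhibition. Compound 1 gives 23700 nM there, and compound 2 gives 22000 nM. Among the measured compounds shown here, the single step between them, a 1.1-fold lower number from compound 1 to compound 2 (0.03 log units; within the scatter), falls within the scatter. Of the two numbers shown, the one for compound 2 is the smaller, but only by a margin within the scatter, so compound 2 is not distinguished from compound 1.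

Compound 3 `CN(C(=O)Nc1ccccc1)c1ccc2[nH]c(-c3n[nH]c4ccccc34)cc2n1` has not yet been measured. It differs from compound 2 in one place: anilino in place of 3-methoxyphenyl on a carbonyl carbon. Cut one bond further out, the change reads (3-methoxyphenyl)carbonyl to phenylcarbamoyl.

For the measured compounds named here, no measured step concerns a change of this kind. Going by the values given here, the only step available, a 1.1-fold lower number from compound 1 to compound 2 (0.03 log units; within the scatter), exchanges one methoxyphenyl for another and leaves the number essentially where it was; it offers no guide to what replacing that ring with anilino does. The expectation is therefore a step of no change at the digits printed from compound 2 to compound 3 (within the scatter), nothing beyond the scatter, held with wide uncertainty. Compound 3 is accordingly estimated at 22000 nM, within a range from 7000 nM to 70000 nM.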

Compound 3, half-maximal inhibitory concentration: 280 nM
Compound 3: middle estimate off by 79-fold (1.90 log units), on the high side; measured number outside the range, below it.
By their numbers in this assay, from the lowest: compound 3; then compounds 2 and 1 (each within the scatter of the next).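

In this assay the position on the carbonyl carbon, which showed no difference when one methoxyphenyl replaced the other, proves highly sensitive to what stands there: the shared core shows a 79-fold lower number from compound 2 to compound 3 (1.90 log units; beyond the scatter) with anilino in place of 3-methoxyphenyl and an 85-fold lower number from compound 1 to compound 3 (1.93 log units; beyond the scatter) with anilino in place of 4-methoxyphenyl. Both steps are large and beyond the scatter, so the amide-to-urea change makes a difference at this position that the move of the methoxy group between the two amides did not. No measurement shown accounts for the size of this gain.

Anilino differs from both methoxyphenyl groups in two ways at once, bringing in a nitrogen on the carbonyl carbon and carrying no methoxy group on its ring, and the compounds shown do not tell these two differences apart. Also open, as far as these compounds go, is whether the number would stay this low with a methoxy group on the anilino ring, or with a benzyl, cyclohexylamino or morpholine group on the carbonyl carbon in its place.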